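Hydroxy for carbamoyl on the diazepane-substituted core

The compounds below may be only part of what the source reports. "The series", "measured", "known", "first", "only" and "open" are said of these compounds alone.

Going by the values given here, compound 3 `NC(=O)c1cncc(N2CCCNCC2)c1` gives 56% in an assay on HEK293 cells with Neuronal acetylcholine receptor; alpha4/beta2 (Homo sapiens) as the target, read by FLIPR and calcium flux (a lower number here means a smaller maximal response, a higher number a larger maximal response), the lowest of the three numbers measured so far. Its nearest neighbour is compound 2 `COc1cncc(N2CCCNCC2)c1`, which reaches 66% in this assay; the gap is within the scatter. Furthest away stands compound 1 `Oc1cc(N2CCCNCC2)cnc1I`, which carries a hydroxy and an iodo on the core and gives 104% in this assay, a number well beyond the scatter from compound 3.

The change to compound 4 `Oc1cncc(N2CCCNCC2)c1` is hydroxy in place of carbamoyl on an aromatic carbon. Among the compounds with values here, the only measured step at this position is a number 10 percentage points lower from compound 2 to compound 3 (within the scatter), where one small group replaced another and the number barely moved. Within the data shown here, no step isolates the hydroxy alone; compound 1 carries it together with an iodo, so its high value cannot be laid to the hydroxy.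

For compound 4 an estimated step of a number 16 percentage points higher from compound 3 to compound 4 (beyond the scatter) in this assay is expected, upward but small, with a wide range because compound 1 gives 104%. Compound 4 is therefore expected to reach 72%, between 48% and 104%.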

Compound 4, largest response reached (reported as efficacy), in percent of the reference or control that the assay uses: 120%
Compound 4: middle estimate off by 48 percentage points, on the low side; the whole stated range lies below it.
By their numbers in this assay, from the lowest: compounds 3 and 2 (each within the scatter of the next); then compound 1; then compound 4.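

In this assay the hydroxy on the shared core goes with a large rise in maximal response over both other groups at this position (a number 64 percentage points higher from compound 3 to compound 4 (beyond the scatter); a number 54 percentage points higher from compound 2 to compound 4 (beyond the scatter)). The second step shows that hydrogen in place of methyl on the oxygen is enough for that rise, so the oxygen alone does not give it, while compound 2 and compound 3 remain within the scatter of each other. Removing the iodo gives a modest further rise (a number 16 percentage points higher from compound 1 to compound 4 (beyond the scatter)), so the high response of compound 1 cannot be credited to the iodo, and both compounds with the hydroxy lie well above the two without it.

Nothing available explains why the hydroxy stands apart. Open, from the compounds shown here alone, is whether an amino group or a carboxylic acid on this aromatic carbon would keep the response of compound 4.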